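Ester to ether exchange: cytotoxicity notes on compound 3

The source may hold more compounds than are shown below. What is called first, only, known or untested is meant among the compounds shown, and "the series" means these compounds.

Compound 1 `CCCOC(=O)c1c(C)coc1-c1ccc2c(CC)cccc2c1OC` was examined in a functional assay on A549 cells (Homo sapiens) for cytotoxicity, read by MTT assay, with a stated time of 72 h; on this read-out higher numbers stand for an effect only at larger amounts of compound and lower numbers for an effect already at smaller amounts. In this assay compound 1 gives > 10 ug/mL, which is a limit of the assay and not a number. Within the data shown here, compound 2 `CCc1cccc2c(OC)c(-c3occ(C)c3C(=O)On3nnc4ccccc43)ccc12` is the only other measured member; in this assay compound 2 gives > 10 ug/mL, likewise a limit. The measured step that the two limits leave unreadable from compound 1 to compound 2 is therefore unreadable, both values sitting at the limit of > 10 ug/mL in this assay, at which 2 of the 2 values shown sit.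

Compound 3 `CCOCc1c(C)coc1-c1ccc2c(CC)cccc2c1OC` differs from compound 1 by ethoxymethyl in place of propoxycarbonyl on an aromatic carbon. Among the measured compounds shown here, no measured step touches this position, and the one measured step gives no readable size, so no direction and no size beyond the scatter can be derived for this exchange; the starting point for compound 1 is itself only a limit.

Compound 3 is expected at 15 ug/mL, within 5 ug/mL to 50 ug/mL, most probably reported again as a limit. The step that the limit leaves unreadable from compound 1 to compound 3 that this estimate means is expected to be none that can be read.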

Compound 3, concentration for half-maximal effect: > 10 ug/mL
Compound 3 gave a limit, no number; the forecaster's own chance of this, stated with the estimate: 70%; the middle value does not contradict the limit.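

Compound 1 and compound 3 both sit at a limit of the assay and not at a number, so the exchange of propoxycarbonyl for ethoxymethyl gives no readable step: the limit of > 10 ug/mL in this assay, at which 3 of the 3 values shown sit.

The compounds shown leave open what actual value any of them would reach in this assay, and so what size this exchange has.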